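Aryl amine in place of benzylic amine on the shared core

A few compounds are considered here, and "the series" means these few. Any claim that something is new, unique, unknown or untested is made for them only; others in the source may bear on it.

For the measured compounds named here, the three measured members share the core of compound 1 `NS(=O)(=O)OC[C@@H]1C[C@@H](n2nnc3c(NCc4ccco4)ncnc32)C[C@@H]1O` and differ only in the group carried on the aromatic nitrogen. In an assay on a protein complex for inhibition of NEDD8 activating enzyme (Homo sapiens), read by HTRF, with a stated time of 2 h, in the presence of a further agent that is not named here (on this read-out lower numbers stand for stronger inhibition and higher numbers for weaker inhibition), compound 1 gives 30.6 nM, the highest of the two plain numbers shown. Compound 2 `CCCCCCNc1ncnc2c1nnn2[C@@H]1C[C@@H](COS(N)(=O)=O)[C@@H](O)C1` gives 21.1 nM in this assay, and the step of a 1.5-fold lower number from compound 1 to compound 2 (0.16 log units; within the scatter) stays within the scatter. Compound 3 `NS(=O)(=O)OC[C@@H]1C[C@@H](n2nnc3c(Nc4n[nH]c5ccccc45)ncnc32)C[C@@H]1O` reports only a limit in this assay, > 10000 nM. The steps of an at least 320-fold higher number from compound 1 to compound 3 (2.51 log units; beyond the scatter) and an at least 470-fold higher number from compound 2 to compound 3 (2.67 log units; beyond the scatter) are both large, and both run into that limit (the limit of > 10000 nM in this assay, at which 1 of the 3 values shown sits).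

Compound 4 `NS(=O)(=O)OC[C@@H]1C[C@@H](n2nnc3c(Nc4cnc5ccccn45)ncnc32)C[C@@H]1O` is not yet measured. It differs from compound 1 by a group of 9 heavy atoms (7 carbon, 2 nitrogen; one five-membered aromatic ring with 2 hetero atoms, one six-membered aromatic ring with 1 hetero atom) in place of a group of 6 heavy atoms (5 carbon, 1 oxygen; one five-membered aromatic ring with 1 hetero atom), on a nitrogen on an aromatic ring; in words, a group of 9 heavy atoms (7 carbon, 2 nitrogen; one five-membered aromatic ring with 2 hetero atoms, one six-membered aromatic ring with 1 hetero atom) in place of a group of 6 heavy atoms (5 carbon, 1 oxygen; one five-membered aromatic ring with 1 hetero atom), on a nitrogen on an aromatic ring. As in compound 3, the entering group is an aromatic ring bound directly to that nitrogen rather than through a saturated chain carbon, so the steps into compound 3 bear most on this change. A large rise in the number is therefore expected in this assay, a 200-fold higher number from compound 1 to compound 4 (2.29 log units; beyond the scatter). For compound 4 the estimate is 6000 nM, with a range from 800 nM to 40000 nM, and a real chance that only a limit is reported.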

Compound 4, half-maximal inhibitory concentration: > 10000 nM
Compound 4: no number, only a limit; the forecaster's own chance of this, stated with the estimate: 45%; middle value at least 1.6-fold (0.22 log units) away from the limit.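

In this assay, a second aromatic ring bound directly to the nitrogen gives a limit rather than a number, with an at least 320-fold higher number from compound 1 to compound 4 (2.51 log units; beyond the scatter) and an at least 470-fold higher number from compound 2 to compound 4 (2.67 log units; beyond the scatter) both large, so the loss is not confined to the 1H-indazol-3-yl group of compound 3. Among the four compounds shown, the two groups attached through a saturated chain carbon (compound 1 and compound 2) give plain numbers, while the two aromatic rings bound directly to the nitrogen (compound 3 and compound 4) do not, and no compound goes against this: the limit of > 10000 nM in this assay, at which 2 of the 4 values shown sit. Compound 3 and compound 4 both sit at a limit and the step between them cannot be read, so replacing a six-membered ring of carbon only with one carrying 1 hetero atom cannot be ranked.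

Direct attachment and the larger two-ring group change together in compound 3 and compound 4, and the compounds shown do not separate the two. Going by these compounds, a phenyl group on that nitrogen, or a (1H-indazol-3-yl)methyl group held through a saturated chain carbon, would pull them apart, and the actual values of compound 3 and compound 4 remain unknown.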